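The source may report more compounds than this note shows. Statements on the series, on what has been measured and on what is new or still open speak of the compounds shown alone.

Measured so far:
compound 1, `CCS(=O)(=O)Nc1ccc(NC(=O)c2ccc(Cl)c([N+](=O)[O-])c2)cc1C`, 141000 nM in an ADME assay on RAW264.7 cells (Mus musculus) for cytotoxicity, read by MTT assay, with a stated time of 48 h; a higher number here means a weaker inhibitor, a lower number a stronger inhibitor
compound 2, `CS(=O)(=O)Nc1ccc(NC(=O)c2ccc(Cl)c([N+](=O)[O-])c2)cc1Cl`, 43600 nM in this assay

Of the two numbers, compound 2 stands lowest; the nearest is compound 1, whose number is higher by a margin beyond the usual scatter. Among the compounds with values here, compound 1 and compound 2 differ in two places at once, so no single step between them can be read off. Compound 3, `CCS(=O)(=O)Nc1ccc(NC(=O)c2ccc(Cl)c([N+](=O)[O-])c2)cc1Cl`, has not yet been measured. It differs from compound 2 in one place: methyl in place of hydrogen on a saturated chain carbon bound to a sulfonyl sulfur. Within the data shown here, no measured pair shows this change on its own. The expected step from compound 2 to compound 3 in this assay is taken to be small, with no clear direction, most likely within the scatter: a 1.1-fold higher number from compound 2 to compound 3 (0.06 log units; within the scatter) is the estimated step. Compound 3 is therefore expected to give about 50000 nM, with a likely range from 18000 nM to 140000 nM.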

Compound 3, half-maximal inhibitory concentration: 125000 nM
The estimate for compound 3 lay 2.5-fold (0.40 log units) below the measured number; the range from low to high includes it.
By their numbers in this assay, from the lowest: compound 2; then compounds 3 and 1 (each within the scatter of the next).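

In this assay, methyl in place of hydrogen on a saturated chain carbon bound to a sulfonyl sulfur gives a 2.9-fold higher number from compound 2 to compound 3 (0.46 log units; beyond the scatter) and so turns methylsulfonyl into ethylsulfonyl: this single added carbon is enough to shift the reading towards weaker cytotoxicity. On the aromatic carbon, chloro in place of methyl gives a 1.1-fold lower number from compound 1 to compound 3 (0.05 log units; within the scatter) with the ethylsulfonyl group present, so this swap leaves the reading within the scatter. Nothing available here accounts for the effect of the added carbon.

From the compounds shown here alone, it remains open whether a longer chain, such as propyl, on the sulfonyl sulfur would continue the same trend or reverse it. Going by these compounds, it is also open whether chloro and methyl on the aromatic carbon would still read alike with methylsulfonyl in place of ethylsulfonyl.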